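Anilino for phenyl on the carbonyl of compound 2

The compounds below may be only part of what the source reports. "The series", "measured", "known", "first", "only" and "open" are said of these compounds alone.

In a physicochemical assay for solubility, with a stated time of 24 h, at pH 2.2 (a higher number here means a more soluble compound, a lower number a less soluble compound), compound 2 (`COC(=O)c1ccc2ccc(C(=O)c3ccccc3)c-2cc1`) gives < 1 ug/mL as a limit, not a number. Compound 3 (`COC(=O)c1ccc2c(C(=O)c3ccccc3)cc(C(=O)c3ccccc3)c-2cc1`) gives < 1 ug/mL as a limit too. Compound 1 (`COC(=O)c1ccc2ccc(C(=O)N(C)C)c-2cc1`) gives > 64 ug/mL as a limit as well.

Phenyl in place of dimethylamino on a carbonyl carbon gave an at least 64-fold lower number from compound 1 to compound 2 (1.80 log units; beyond the scatter) as the one large step. Benzoyl in place of hydrogen on an aromatic carbon gave a step that the two limits leave unreadable from compound 2 to compound 3 and so adds little here.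

Compound 4 (`COC(=O)c1ccc2ccc(C(=O)Nc3ccccc3)c-2cc1`) has anilino in place of phenyl on a carbonyl carbon and keeps the aromatic ring that came with an at least 64-fold lower number from compound 1 to compound 2 (1.80 log units; beyond the scatter) on that carbonyl. A small upward move is expected, estimated as a number no lower from compound 2 to compound 4 (the limit leaves the size open) at most modest in size. For compound 4 the estimated solubility is 1 ug/mL with an expected range from 0.4 ug/mL to 5 ug/mL and a report as a limit remains likely.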

Compound 4, solubility: < 1 ug/mL
Compound 4 gave a limit, no number; the forecaster's own chance of this, stated with the estimate: 60%; the middle value sits exactly at the limit.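

In this assay, replacing dimethylamino with anilino gave an at least 64-fold lower number from compound 1 to compound 4 (1.80 log units; beyond the scatter), so a nitrogen on the carbonyl carbon does not by itself keep the reading high. In the compounds shown, both phenyl and anilino on that carbon go with the low reading. The step from compound 2 to compound 4 cannot be read, so phenyl and anilino cannot be ranked: the limit of < 1 ug/mL in this assay, at which 3 of the 4 values shown sit.

Still open, from the compounds shown here alone, is how a piperazine amide on that carbonyl carbon would read in this assay. Also open, going by these compounds, is how far the true values of compound 2, compound 3 and compound 4 lie beyond their shared limit.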